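A few compounds are considered here, and "the series" means these few. Any claim that something is new, unique, unknown or untested is made for them only; others in the source may bear on it.

Compound 3 `CC(C)OC(=O)N1CCC(Oc2ncnc3c2CCN3c2ccc(C#N)cn2)CC1` gives 794 nM in a functional assay on CHO-K1 cells for agonist activity at Glucose-dependent insulinotropic receptor (Homo sapiens), read by a luciferase reporter, with a stated time of 5 h (on this read-out lower numbers stand for an effect already at smaller amounts and higher numbers for an effect only at larger amounts of compound), the higher of the two numbers that exist for this set; compound 1 `Cc1nc(OC2CCN(C(=O)OC(C)(C)C)CC2)c2c(n1)N(c1ccc(S(C)(=O)=O)cc1F)CC2`, the nearest neighbour of compound 3 in structure, gives in this assay, for compound 1, 126 nM, a gap that lies beyond the scatter. Compound 2 `CNc1nc(OC2CCN(C(=O)OC(C)C)CC2)c2c(n1)N(c1ccc(S(C)(=O)=O)cc1F)CC2` reaches only a limit in this assay, > 10000 nM, and so supplies no number. Compound 4 `CC(C)OC(=O)N1CCC(Oc2ncnc3c2CCN3c2ccc([S@@+](C)[O-])c(F)c2)CC1` arises from compound 3 through (a group of 10 heavy atoms (7 carbon, 1 oxygen, 1 fluorine, 1 sulfur; one six-membered aromatic ring of carbon only) in place of a group of 8 heavy atoms (6 carbon, 2 nitrogen; one six-membered aromatic ring with 1 hetero atom), on a nitrogen on an aromatic ring in a ring), a group of 10 heavy atoms (7 carbon, 1 oxygen, 1 fluorine, 1 sulfur; one six-membered aromatic ring of carbon only) in place of a group of 8 heavy atoms (6 carbon, 2 nitrogen; one six-membered aromatic ring with 1 hetero atom), on a nitrogen on an aromatic ring in a ring. Within the data shown here, no measured step covers this change; given the number of compound 1 126 nM, a moderate move towards lower numbers is expected, a 3.2-fold lower number from compound 3 to compound 4 (0.50 log units; beyond the scatter). Compound 4 is therefore estimated at 250 nM, between 80 nM and 800 nM.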

Compound 4, half-maximal effective concentration: 631 nM
Beside the measured number, compound 4's estimate is 2.5-fold (0.40 log units) below it; the range from low to high includes it.
By their numbers in this assay, from the lowest: compound 1; then compounds 4 and 3 (each within the scatter of the next). At a limit, above all of these: compound 2.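

In this assay the exchange on a nitrogen on an aromatic ring in a ring brings a 1.3-fold lower number from compound 3 to compound 4 (0.10 log units; within the scatter) and so does not separate 5-cyanopyridin-2-yl from the entering group with its six-membered aromatic ring of carbon only. Among these compounds, at this position, the two groups can therefore stand in for each other on this read-out, which the earlier compounds, differing in more than one place, could not show. Nothing measured here bears on the reason for this.

Going by these compounds, whether an unsubstituted phenyl or a pyridine carrying an amine would behave the same way at this nitrogen remains open.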